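The source may report more compounds than this note shows. Statements on the series, on what has been measured and on what is new or still open speak of the compounds shown alone.

Compound 2 `COc1ncc(-c2ccc3ncnc(N[C@H]4CCCN(C(=O)CCBr)C4)c3c2)cc1C#N` gives 15 nM in a functional assay on SU-DHL-6 cells (Homo sapiens) for antiproliferative activity, read by MTT assay (on this read-out higher numbers stand for weaker inhibition and lower numbers for stronger inhibition), the lowest of the three numbers measured. Compound 3 `COc1ncc(-c2ccc3ncnc(N[C@H]4CCCN(C(=O)C(F)(F)F)C4)c3c2)cc1C#N` gives 210 nM and compound 1 `COc1ncc(-c2ccc3ncnc(N[C@H]4CCCN(C(=O)C5CCNCC5)C4)c3c2)cc1C#N` gives 2440 nM. The measured steps are a 160-fold lower number from compound 1 to compound 2 (2.21 log units; beyond the scatter), a 12-fold lower number from compound 1 to compound 3 (1.07 log units; beyond the scatter) and a 14-fold higher number from compound 2 to compound 3 (1.15 log units; beyond the scatter). Compound 4 `COc1ncc(-c2ccc3ncnc(N[C@H]4CCCN(C(=O)c5coc([N+](=O)[O-])c5)C4)c3c2)cc1C#N` differs from compound 2 at the same carbonyl carbon: 5-nitrofuran-3-yl in place of 2-bromoethyl on a carbonyl carbon. Among the measured compounds shown here, in both measured comparisons at that carbon compound 2 holds the lowest number by a large margin, so a higher number is expected for compound 4 as well, although no measured step puts an aromatic ring at this position. For compound 4 the expected step is a 20-fold higher number from compound 2 to compound 4 (1.30 log units; beyond the scatter), and the estimate is 300 nM, with a range from 60 nM to 1500 nM.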

Compound 4, half-maximal inhibitory concentration: 140 nM
Beside the measured number, compound 4's estimate is 2.1-fold (0.33 log units) above it; the range from low to high includes it.
By their numbers in this assay, from the lowest: compound 2; then compounds 4 and 3 (each within the scatter of the next); then compound 1.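

Placing an aromatic ring on the carbonyl carbon gives a 9.3-fold higher number from compound 2 to compound 4 (0.97 log units; beyond the scatter) and so leaves 2-bromoethyl with the lowest number, yet the same ring gives a 17-fold lower number from compound 1 to compound 4 (1.24 log units; beyond the scatter) against piperidin-4-yl. With a 1.5-fold lower number from compound 3 to compound 4 (0.18 log units; within the scatter) as the remaining step, 5-nitrofuran-3-yl and trifluoromethyl cannot be told apart here, although one is a ring of 8 heavy atoms and the other has no ring. No available evidence explains these differences.

The compounds shown leave open whether the nitro group matters, since a plain furan-3-yl is not among them. They also leave open whether the bromine matters, since a plain ethyl is not among them.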